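Compound 3 Expected From Compound 1

The source may hold more compounds than are shown below. What is called first, only, known or untested is meant among the compounds shown, and "the series" means these compounds.

Going by the values given here, compound 1 `NC(=O)c1c(NC(=O)c2ccccc2Cl)sc2c1CCN(C(=S)Nc1cc(C(F)(F)F)cc(C(F)(F)F)c1)C2` gives 6500 nM in a functional assay on HL-60 cells (Homo sapiens) for antiproliferative activity, with a stated time of 24 h (on this read-out lower numbers stand for stronger inhibition and higher numbers for weaker inhibition), the lower of the two numbers measured so far; compound 2 `Cc1ccccc1C(=O)Nc1sc2c(c1C(N)=O)CCN(C(=S)Nc1ccccc1C(F)(F)F)C2` gives 23200 nM in this assay, a gap beyond the usual scatter. Compound 3 `NC(=O)c1c(NC(=O)c2ccc(C(F)(F)F)cc2)sc2c1CCN(C(=S)Nc1cc(C(F)(F)F)cc(C(F)(F)F)c1)C2` differs from compound 1 only by 4-(trifluoromethyl)phenyl in place of 2-chlorophenyl on a carbonyl carbon. Among the compounds with values here, no measured pair shows this exchange, so its effect on this assay is unknown. A step of a 1.1-fold lower number from compound 1 to compound 3 (0.03 log units; within the scatter) is expected, likely no larger than the scatter in either direction. Compound 3 is therefore estimated at 6000 nM, with a range from 2000 nM to 20000 nM.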

Compound 3, half-maximal inhibitory concentration: 16300 nM
Compound 3: the middle estimate sits 2.7-fold (0.43 log units) below what was measured; the measured number falls inside the stated range.
By their numbers in this assay, from the lowest: compound 1; then compounds 3 and 2 (each within the scatter of the next).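

In this assay, the group on this carbonyl carbon matters: 4-(trifluoromethyl)phenyl in place of 2-chlorophenyl gives a 2.5-fold higher number from compound 1 to compound 3 (0.40 log units; beyond the scatter), with the rest of the molecule unchanged. Going by these compounds alone, this is the first exchange here that can be read on its own, as compound 1 and compound 2 differ in more than one place. No measurement shown accounts for the step.

On these data alone, it remains open how phenyl, 4-chlorophenyl or 2-(trifluoromethyl)phenyl would read on this carbonyl carbon, which would separate the substituent from its place on the ring. As far as these compounds go, whether cyclohexyl could stand there is also open.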